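The compounds below may be only part of what the source reports. "The series", "measured", "known", "first", "only" and "open" are said of these compounds alone.

Measured in a functional assay on MIA PaCa-2 cells (Homo sapiens) for cytotoxicity, read by MTT assay, with a stated time of 72 h; on this read-out lower numbers stand for stronger inhibition and higher numbers for weaker inhibition:
- compound 1 `COC1=CC(=O)c2c(COc3ccccc3)c(C)n(C)c2C1=O`: 409 nM
- compound 2 `COC1=CC(=O)c2c(COc3cccc([N+](=O)[O-])c3)c(C)n(C)c2C1=O`: 257 nM
- compound 3 `COC1=CC(=O)c2c(COc3ccccc3[N+](=O)[O-])c(C)n(C)c2C1=O`: 178 nM

In this assay, compound 1 cannot be separated from one of its two analogues but is separated from the other. The comparison shows a 1.6-fold lower number from compound 1 to compound 2 (0.20 log units; within the scatter), and also a 2.3-fold lower number from compound 1 to compound 3 (0.36 log units; beyond the scatter).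

The next analogue is compound 4 `COC1=CC(=O)c2c(COc3ccc(C#N)cc3)c(C)n(C)c2C1=O`, which is related to compound 1 by cyano in place of hydrogen on an aromatic carbon. In words, this is cyano in place of hydrogen on an aromatic carbon, or phenyl to 4-cyanophenyl.

Among the compounds with values here, no measured compound carries a cyano group, and none carries a group para to a large group on that ring. The nearest evidence is therefore the pair of nitro steps, which also replace hydrogen on an aromatic carbon. One of them stays within the scatter and the other is modest: a 1.6-fold lower number from compound 1 to compound 2 (0.20 log units; within the scatter) and a 2.3-fold lower number from compound 1 to compound 3 (0.36 log units; beyond the scatter). Both point to lower numbers, so a small step in that direction is expected in this assay, and a result within the scatter of compound 1 would be no surprise. The expected step is a 1.5-fold lower number from compound 1 to compound 4 (0.16 log units; within the scatter). For compound 4 the estimated value is 280 nM, with an expected range of 130 nM to 570 nM.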

Compound 4, half-maximal inhibitory concentration: 192 nM
Beside the measured number, compound 4's estimate is 1.5-fold (0.16 log units) above it; the range from low to high includes it.
By their numbers in this assay, from the lowest: compounds 3, 4, 2 and 1 (each within the scatter of the next, the first and the last beyond it).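

Cyano on an aromatic carbon para to a large group, the change from phenyl to 4-cyanophenyl, gives a 2.1-fold lower number from compound 1 to compound 4 (0.33 log units; beyond the scatter) in this assay and is the first reading at this place on the ring. Within the data shown here, compound 4 therefore separates from compound 1 in this assay, and a step beyond the scatter is no longer confined to nitro, with a 2.3-fold lower number from compound 1 to compound 3 (0.36 log units; beyond the scatter) as the only such step until now, while a 1.6-fold lower number from compound 1 to compound 2 (0.20 log units; within the scatter) still leaves compound 2 unseparated from compound 1. Nothing measured on these compounds bears on why the cyano step takes this size.

Open, on these data alone, is whether this step belongs to cyano itself or would follow from other groups on the same carbon, such as an amine, a methoxy group or a carboxylic acid. Also open, as far as these compounds go, is how cyano behaves at the places held by the nitro groups of compound 2 and compound 3, and how nitro behaves at the place held by cyano in compound 4.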